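Hydroxyphenyl hydrazone replacing a furan

The source may report more compounds than this note shows. Statements on the series, on what has been measured and on what is new or still open speak of the compounds shown alone.

In a functional assay on PC-3 cells (Homo sapiens) for antiproliferative activity, read by MTT assay, with a stated time of 72 h (on this read-out higher numbers stand for weaker inhibition and lower numbers for stronger inhibition), compound 3 `O=C(N/N=C/c1ccco1)c1cccc(S(=O)(=O)N2CCOCC2)c1` reports only a limit, > 100000 nM. Compound 1 `C/C(=N\NC(=O)c1cccc(S(=O)(=O)N2CCOCC2)c1)c1cccc(N)c1` likewise reports only a limit in this assay, > 100000 nM. Both sit at the limit of > 100000 nM in this assay, at which 2 of the 3 values shown sit. Compound 2 `C/C(=N\NC(=O)c1cccc(S(=O)(=O)N2CCOCC2)c1)c1cccc(N)c1O` gives 2330 nM in this assay, and the step of an at least 42-fold lower number from compound 1 to compound 2 (1.63 log units; beyond the scatter) lies beyond the scatter. Compound 4 `O=C(N/N=C/c1cc(Br)ccc1O)c1cccc(S(=O)(=O)N2CCOCC2)c1` differs from compound 3 by 5-bromo-2-hydroxyphenyl in place of furan-2-yl on a carbon with a double bond to nitrogen. Going by the values given here, the only measured step involves a hydroxy entering on an aromatic carbon, and it was large; compound 4 also carries a hydroxy on its entering ring, so a downward step beyond the scatter is expected from the limit of compound 3, while the bromine and the ring exchange have no measured counterpart. Compound 4 is therefore estimated at 8000 nM, within 1500 nM to 40000 nM, an expected step of an at least 12-fold lower number from compound 3 to compound 4 (1.09 log units; beyond the scatter).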

Compound 4, half-maximal inhibitory concentration: 7230 nM
Beside the measured number, compound 4's estimate is 1.1-fold (0.04 log units) above it; measured number inside the range.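

In this assay, the exchange on a carbon with a double bond to nitrogen gives an at least 13-fold lower number from compound 3 to compound 4 (1.14 log units; beyond the scatter), so this place can carry a measurable value when 5-bromo-2-hydroxyphenyl replaces furan-2-yl. The step comes from a different place and a different parent than the earlier hydroxy step, but here ring, hydroxy and bromine enter together. Compound 3 stands at a limit, so the step gives only a minimum size: the limit of > 100000 nM in this assay, at which 2 of the 4 values shown sit.

The compounds shown do not separate the contributions of the hydroxy, the bromine and the ring exchange. Going by these compounds, what a methoxy in place of the hydroxy, or chlorine in place of the bromine, would give remains open.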